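The compounds below may be only part of what the source reports. "The series", "measured", "known", "first", "only" and "open" are said of these compounds alone.

Measured compounds:
- compound 1, `CC(C)[C@@H]1CC[C@@H](C)C[C@H]1OC(=O)c1ccccc1Cl`: 5.34
- compound 2, `Cc1ccc(C(=O)O[C@@H]2C[C@H](C)CC[C@H]2C(C)C)cc1`: 5.29

Two esters of the shared core have been run in a physicochemical assay for lipophilicity, measured as octanol-water partition; a lower number here means a more polar compound, a higher number a more lipophilic compound. Compound 1 gives 5.34. Compound 2 gives 5.29. The two values lie within the scatter of each other, so compound 2 cannot be set apart from compound 1 on these numbers; both sit in the same high region of this assay.

The next compound, compound 3, `CC(C)[C@@H]1CC[C@@H](C)C[C@H]1OC(=O)c1ccc(Cl)cc1`, is not yet measured. Relative to compound 2 the change is chloro in place of methyl on an aromatic carbon. No measured pair in the series isolates this exact exchange, so no shown step can be carried over. Going by the values given here, the only guide is that compound 1, which also carries a chloro on its ring, gives 5.34, a value within the scatter of compound 2.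

For compound 3 in this assay the step from compound 2 is expected to be small and upward, a number 0.16 log units higher from compound 2 to compound 3 (within the scatter), likely within the scatter. The estimate for compound 3 is 5.45, with a range from 5.15 to 5.75.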

Compound 3, partition coefficient: 5.34
For compound 3 the middle estimate is 0.11 log units above the measured one, within the range that was stated.
By their numbers in this assay, from the lowest: compounds 2, 1 and 3 (each within the scatter of the next).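

In this assay, the exchange of methyl for chloro on an aromatic carbon, para to a large group, gives a number 0.05 log units higher from compound 2 to compound 3 (within the scatter) and so does not separate the two groups at this position. Compound 1, with its chloro at a different place on the ring, gives 5.34 and compound 3 gives 5.34, so the printed values of this pair coincide and the two chloro placements shown cannot be told apart on these numbers. No independent evidence bears on this result.

The compounds shown carry only methyl or chloro on the ring, which leaves open whether the number in this assay would stay in this region with a group of another kind at the same position, such as an amine, a carboxylic acid or a longer chain. All three are also esters of the shared core, so the contribution of the ester link itself, against an amide for example, remains unresolved.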